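Swapping pyridin-4-yl for 3-fluorophenyl on the shared core

A few compounds are considered here, and "the series" means these few. Any claim that something is new, unique, unknown or untested is made for them only; others in the source may bear on it.

Of the compounds shown here, two sharing one core have been measured so far. In a functional assay on KB-VIN10 cells (Homo sapiens) for inhibition, with a stated time of 72 h (on this read-out lower numbers stand for stronger inhibition and higher numbers for weaker inhibition), compound 1 (`COc1ccc(S(=O)(=O)N2CCc3cccc(-c4ccc([N+](=O)[O-])cc4)c32)cc1`) gives 51.3 nM, while compound 2 (`COc1ccc(S(=O)(=O)N2CCc3cccc(-c4ccncc4)c32)cc1`) gives 106 nM. Compound 2 therefore holds the higher of the two numbers, making it the weaker inhibitor of this pair. The measured step is a 2.1-fold higher number from compound 1 to compound 2 (0.32 log units; beyond the scatter), and it swaps 4-nitrophenyl for pyridin-4-yl.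

Compound 3 (`COc1ccc(S(=O)(=O)N2CCc3cccc(-c4cccc(F)c4)c32)cc1`) has not yet been measured. It keeps the core of compound 2 and changes one group: 3-fluorophenyl in place of pyridin-4-yl on an aromatic carbon. Here 3-fluorophenyl takes the place of pyridin-4-yl on an aromatic carbon. Going by the values given here, only one measured step bears on this change, and it involves the same place. Compound 1, whose group there has a ring of carbon only, stands lower, at 51.3 nM. One modest step is thin evidence, and 3-fluorophenyl is not 4-nitrophenyl, so only a small move is expected. The expected change is a 1.5-fold lower number from compound 2 to compound 3 (0.18 log units; within the scatter), towards a lower number in this assay. For compound 3 the estimated value is 70 nM, with an expected range of 25 nM to 190 nM.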

Compound 3, half-maximal inhibitory concentration: 92.4 nM
Estimate against measurement, compound 3: 1.3-fold (0.12 log units) below; the range from low to high includes it.
By their numbers in this assay, from the lowest: compounds 1, 3 and 2 (each within the scatter of the next, the first and the last beyond it).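

In this assay, placing 3-fluorophenyl at this position in place of pyridin-4-yl gives a 1.1-fold lower number from compound 2 to compound 3 (0.06 log units; within the scatter) and so leaves the two groups indistinguishable on this read-out. Compared with the 4-nitrophenyl group at the same place, the change gives a 1.8-fold higher number from compound 1 to compound 3 (0.26 log units; within the scatter) and therefore does not separate these two compounds either, although compound 1 and compound 2 lie beyond the scatter of each other. Compound 3 thus shows that a ring of carbon only does not by itself give a number clearly apart from that of compound 2, and no measurement to hand explains these results.

All three groups at this position are six-membered aromatic rings, so the compounds shown leave open how the read-out responds when such a ring gives way to an amine, a carboxylic acid or a longer alkyl chain. With only 3-fluorophenyl and 4-nitrophenyl as the substituted carbon rings, they also leave open what a methoxy group or a nitrile on that ring would do.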